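Methoxycarbamoyl on the ring in place of the urea arm

The source may hold more compounds than are shown below. What is called first, only, known or untested is meant among the compounds shown, and "the series" means these compounds.

Compound 1 `O=C1CNC(=O)N1C[C@H]1CN(c2ccc(-n3cc(-c4ccccn4)cn3)c(F)c2)C(=O)O1`: 1.25
Compound 2 `O=C1CSC(=O)N1C[C@H]1CN(c2ccc(-n3cc(-c4ccccn4)cn3)c(F)c2)C(=O)O1`: 2.18
Compound 3 `CCNC(=O)NC[C@H]1CN(c2ccc(-n3cc(-c4ccccn4)cn3)c(F)c2)C(=O)O1`: 2.45

In a physicochemical assay for lipophilicity, read by HPLC, measured as octanol-water partition (a higher number here means a more lipophilic compound, a lower number a more polar compound), compound 3 gives 2.45, the highest of the three numbers. Its nearest neighbour is compound 2, whose value in this assay is 2.18, the step being a number 0.27 log units higher from compound 2 to compound 3 (within the scatter). Compound 1 stands furthest away, at 1.25, the step being a number 1.20 log units higher from compound 1 to compound 3 (beyond the scatter). Between the two imides the step is a number 0.93 log units higher from compound 1 to compound 2 (beyond the scatter).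

Compound 4 `CONC(=O)[C@H]1CN(c2ccc(-n3cc(-c4ccccn4)cn3)c(F)c2)C(=O)O1` is not yet measured. The change from compound 3 is methoxycarbamoyl in place of ((ethylcarbamoyl)amino)methyl on a saturated ring carbon. For the measured compounds named here, none of the measured steps alters this ring carbon; all three swap the group on the saturated chain carbon. They show, through a number 1.20 log units higher from compound 1 to compound 3 (beyond the scatter) and a number 0.27 log units higher from compound 2 to compound 3 (within the scatter), that this assay is sensitive to the group in that region, and that the open-chain urea of compound 3 gives the highest value. Compound 4 drops two heavy atoms, one donor and the chain, and gains an acceptor, so a modest fall is expected. The estimated step is a number 0.55 log units lower from compound 3 to compound 4 (beyond the scatter). Compound 4 is therefore estimated at 1.9, with a range from 1.4 to 2.4.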

Compound 4, partition coefficient: >= 1.58
Compound 4 was reported as a limit; the forecaster's own chance of this, stated with the estimate: 0%; the middle value does not contradict the limit.
By their numbers in this assay, from the lowest: compound 1; then compounds 2 and 3 (each within the scatter of the next).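

In this assay compound 4 is reported as a limit and not as a number: the limit of >= 1.58 in this assay, at which 1 of the 4 values shown sits. For the compounds shown here, the earlier compounds differed only in the group on the saturated chain carbon, whereas this change falls on the saturated ring carbon next to the ring oxygen, and the one step that can be read across it is a number at least 0.33 log units higher from compound 1 to compound 4 (beyond the scatter), with methoxycarbamoyl in place of (2,5-dioxoimidazolidin-1-yl)methyl. The steps to compound 4 from compound 2 and from compound 3 cannot be read, so the result places compound 4 clear of compound 1 but does not settle where it stands against the other two.

Going by these compounds, the exact value of compound 4 stays open, and with it the size and direction of any change on going from ((ethylcarbamoyl)amino)methyl to methoxycarbamoyl. Also open is how this assay would read with a carboxylic acid, an amine or a longer chain in place of methoxycarbamoyl on this saturated ring carbon, as the compounds shown hold none of these groups there.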